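The source may report more compounds than this note shows. Statements on the series, on what has been measured and on what is new or still open speak of the compounds shown alone.

Within the data shown here, in a functional assay on HepG2 cells (Homo sapiens) for antiproliferative activity, read by MTT assay, with a stated time of 72 h (on this read-out lower numbers stand for stronger inhibition and higher numbers for weaker inhibition), compound 1 `COc1ncc(-c2ccc3c(c2)NC(=O)CO3)cc1NS(=O)(=O)c1ccc(F)cc1` gives 6590 nM, the only exact number available so far. Compound 2 `O=C1COc2ccc(-c3cnc(Cl)c(NS(=O)(=O)c4ccc(F)cc4)c3)cc2N1c1ccc(F)cc1` is reported at > 40000 nM, which is a limit of the assay and not a number. The next compound to consider is compound 3 `COc1ncc(-c2ccc3c(c2)N(c2ccccc2)C(=O)CO3)cc1NS(=O)(=O)c1ccc(F)cc1`, which keeps the core of compound 1 but has phenyl in place of hydrogen on an amide-type nitrogen in a ring. Among the measured compounds shown here, no measured pair here differs in one place only, and the data therefore give no direct size for this change. The estimated change, a 1.3-fold lower number from compound 1 to compound 3 (0.12 log units; within the scatter), is expected to be none beyond the usual scatter in this assay, although either direction remains possible. For compound 3, the expected value is 5000 nM, with an estimated range from 600 nM to 30000 nM.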

Compound 3, half-maximal inhibitory concentration: 14000 nM
Compound 3: the middle estimate sits 2.8-fold (0.45 log units) below what was measured, and the stated range covers the measured number.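

At the amide-type nitrogen in a ring, this assay now gives a direct size for this change: a 2.1-fold higher number from compound 1 to compound 3 (0.33 log units; beyond the scatter). The hydrogen on this nitrogen can therefore give way to phenyl with a modest weakening and not a complete loss of activity, since compound 3 still gives an exact number. Compound 2 carries a limit of the assay and not a number, so it adds no size of its own: the limit of > 40000 nM in this assay, at which 1 of the 3 values shown sits.

This single step leaves open whether the weakening belongs to phenyl in particular or would follow from any group on this nitrogen, and it gives no reason for the change. Methyl, a longer chain such as propyl, or a chain ending in an amine at the same place would help to separate these possibilities.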